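Moving the ring nitrogen within an isoquinoline urea

The source may report more compounds than this note shows. Statements on the series, on what has been measured and on what is new or still open speak of the compounds shown alone.

Among the compounds with values here, compound 2 `C[C@@H]1CN([C@@H](C)CO)C(=O)c2cccc(NC(=O)Nc3cccc4cnccc34)c2O[C@H]1CN(C)S(=O)(=O)c1ccc2c(c1)OCCO2` is measured in a physicochemical assay for solubility, read by HPLC, in phosphate buffer, measured as thermodynamic solubility, with a stated time of 24 h, at pH 7.4 (a lower number here means a less soluble compound, a higher number a more soluble compound), at 60500 nM, the highest of the two numbers so far. Its nearest neighbour, compound 1 `C[C@@H]1CN([C@@H](C)CO)C(=O)c2cccc(NC(=O)N(C)c3cccc4ccccc34)c2O[C@H]1CN(C)S(=O)(=O)c1ccc2c(c1)OCCO2`, gives 11200 nM in this assay; the step of a 5.4-fold higher number from compound 1 to compound 2 (0.73 log units; beyond the scatter) is the only measured one here. Compound 3 `C[C@@H]1CN([C@@H](C)CO)C(=O)c2cccc(NC(=O)Nc3cccc4ccncc34)c2O[C@H]1CN(C)S(=O)(=O)c1ccc2c(c1)OCCO2` differs from compound 2 by isoquinolin-8-yl in place of isoquinolin-5-yl on an amide-type nitrogen. Within the data shown here, no measured step bears on a change of this kind: the step from compound 1 to compound 2 swaps one aromatic ring system and the methyl on the urea nitrogen for another, whereas here the atoms stay the same and only their joining moves. With nothing pointing either way, the estimated step of a 1.1-fold lower number from compound 2 to compound 3 (0.04 log units; within the scatter) is expected to stay within the scatter. Compound 3 is therefore expected to give 55000 nM in this assay, with a range from 22000 nM to 130000 nM.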

Compound 3, solubility: 101000 nM
Beside the measured number, compound 3's estimate is 1.8-fold (0.26 log units) below it; measured number inside the range.
By their numbers in this assay, from the lowest: compound 1; then compounds 2 and 3 (each within the scatter of the next).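

In this assay, moving the attachment from isoquinolin-5-yl to isoquinolin-8-yl on the amide-type nitrogen gives a 1.7-fold higher number from compound 2 to compound 3 (0.22 log units; within the scatter), so this position tolerates the shift without a change that can be read beyond the scatter. Against methyl(naphthalen-1-yl)amino, the second isomer also stands clear, with a 9.0-fold higher number from compound 1 to compound 3 (0.96 log units; beyond the scatter), so the gap seen with isoquinolin-5-yl holds for both attachments. No measurement at hand accounts for either step.

The steps from compound 1 replace the ring system and the methyl together, so the compounds shown leave open how much each part contributes. They also leave open how a plain naphthalen-1-yl on the same nitrogen without the methyl, or an isoquinoline carrying an amine, would read here.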